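This account rests on a few compounds, and the source may have more. Where it says the series, first, only, none or still open, it means among the compounds named here.

Of the compounds shown here, two sharing one core have been measured in an assay (strain Wistar) for displacement of a labelled ligand from adenosine receptor A1 (Rattus norvegicus), read by scintillation counting; a lower number here means a stronger inhibitor, a higher number a weaker inhibitor. Compound 1 `CCOc1ccccc1C(=O)Nc1nc(-c2ccccc2)nc2c1nnn2Cc1ccccc1` gives 1850 nM. Compound 2 `COc1ccc(Cl)cc1C(=O)Nc1nc(-c2ccccc2)nc2c1nnn2Cc1ccccc1` gives 7150 nM. Within the data shown here, the only recorded step, a 3.9-fold higher number from compound 1 to compound 2 (0.59 log units; beyond the scatter), comes from putting 5-chloro-2-methoxyphenyl in place of 2-ethoxyphenyl on a carbonyl carbon. Among the measured compounds shown here, of the two numbers, compound 2 stands at the higher, weaker end, with compound 1 as its only and nearest neighbour. Compound 3 `O=C(Nc1nc(-c2ccccc2)nc2c1nnn2Cc1ccccc1)c1cccc([N+](=O)[O-])c1` has not yet been measured; it differs from compound 2 by 3-nitrophenyl in place of 5-chloro-2-methoxyphenyl on a carbonyl carbon. For the measured compounds named here, no measured step involves a nitrophenyl group, so the single step available bears on it only loosely, by showing that exchanging the whole aryl group at this carbonyl shifts this assay by a modest amount. The step from compound 2 to compound 3 is therefore expected to be a 1.4-fold lower number from compound 2 to compound 3 (0.16 log units; within the scatter), with no firm direction. Compound 3 is estimated at 5000 nM, within a range from 1500 nM to 17000 nM.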

Compound 3, inhibition constant: 77 nM
Beside the measured number, compound 3's estimate is 65-fold (1.81 log units) above it, outside the stated range (below it).
By their numbers in this assay, from the lowest: compound 3; then compound 1; then compound 2.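

Changing the aryl group on this carbonyl carbon can move this assay much further than the first step suggested: alongside the modest 3.9-fold higher number from compound 1 to compound 2 (0.59 log units; beyond the scatter), the 3-nitrophenyl group gives a 93-fold lower number from compound 2 to compound 3 (1.97 log units; beyond the scatter) and a 24-fold lower number from compound 1 to compound 3 (1.38 log units; beyond the scatter). Both of these steps are large and beyond the scatter, which makes compound 3 the strongest inhibitor of the three and shows that this position can tolerate a group with no alkoxy substituent. No evidence is available to explain this gain.

Each step replaces the whole aryl group, so the compounds shown cannot separate the effect of gaining the nitro group from that of losing the ethoxy, methoxy or chloro substituents. From the compounds shown here alone, it also remains open whether a plain phenyl, or a 3-aminophenyl or 3-cyanophenyl group, would match 3-nitrophenyl here.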